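Purine series: second chloro on the core of compound 2

The compounds below may be only part of what the source reports. "The series", "measured", "known", "first", "only" and "open" are said of these compounds alone.

Measured so far:
compound 1, `ClCc1ccccc1Cn1cnc2c(Cl)nc(Cl)nc21` — 3230 nM
compound 2, `ClCc1cccc(Cn2cnc3ncnc(Cl)c32)c1` — 29500 nM
compound 3, `ClCc1ccc(Cn2cnc3nc(Cl)nc(Cl)c32)cc1` — 3460 nM

All three numbers come from a functional assay on EKVX cells (Homo sapiens) for cytotoxicity, read by sulforhodamine B assay, with a stated time of 48 h; on this read-out lower numbers stand for stronger inhibition of growth and higher numbers for weaker inhibition of growth. Compound 2 stands highest of the three. Its nearest neighbour is compound 3, whose number is lower by a margin beyond the scatter; compound 1 lies furthest, again lower and again beyond the scatter. Compound 1 and compound 3 are within the scatter of each other, so no order between them is claimed. Among the measured compounds shown here, no pair of measured compounds differs in a single place, so no step between measured compounds can be stated.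

Compound 4, `ClCc1cccc(Cn2cnc3nc(Cl)nc(Cl)c32)c1`, is the next point. It differs from compound 2 by chloro in place of hydrogen on an aromatic carbon. For the measured compounds named here, compound 2 is the only member carrying a single chloro on the core, and it is also the only member with a high number; compound 1 and compound 3 both carry two chloro groups on the core and both sit far lower. Going by the values given here, the benzyl attachment differs across these compounds as well, so the comparison is not clean, but it is the only guide available.

The expected step of a 6.6-fold lower number from compound 2 to compound 4 (0.82 log units; beyond the scatter) is therefore downward and beyond the scatter. Compound 4 is estimated at 4500 nM, with a range from 1500 nM to 15000 nM.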

Compound 4, concentration for total growth inhibition: 2130 nM
For compound 4 the middle estimate is 2.1-fold (0.32 log units) above the measured one; the range from low to high includes it.
By their numbers in this assay, from the lowest: compounds 4, 1 and 3 (each within the scatter of the next); then compound 2.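

In this assay, chloro in place of hydrogen on the aromatic carbon between two ring nitrogen atoms gives a 14-fold lower number from compound 2 to compound 4 (1.14 log units; beyond the scatter), a large step and the first in the series that can be read with only one place changed. The link between the second chloro on the core and the lower number therefore no longer rests only on compounds whose benzyl attachment also differs, and this position is shown to be one where a single chlorine atom moves the number well beyond the scatter. Nothing on hand explains the size or direction of this step.

Whether the step belongs to chloro itself stays open, as the compounds shown do not tell whether an amine or a methoxy group on the same carbon would lower the number in the same way. The compounds shown also hold no single-chloro partner for compound 1 or compound 3, so it stays open whether the step carries over to their benzyl attachments.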